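The source may hold more compounds than are shown below. What is called first, only, known or untested is meant among the compounds shown, and "the series" means these compounds.

Compound 1 `FC(F)(F)c1ccc(CSc2nc(Nc3ccccc3C(F)(F)F)c3ccccc3n2)cc1` is characterised in a functional assay on MDA-MB-231 cells (Homo sapiens) for cytotoxicity, read by MTT assay, with a stated time of 72 h; on this read-out higher numbers stand for weaker inhibition and lower numbers for stronger inhibition. Compound 1 gives only a limit there, > 50000 nM, so its standing is known from one side alone. Two measured neighbours exchange the same group on the shared core. Compound 2 `FC(F)(F)c1ccc(CSc2nc(Nc3cccc(Cl)c3)c3ccccc3n2)cc1` gives 18000 nM, a move of an at least 2.7-fold lower number from compound 1 to compound 2 (0.44 log units; beyond the scatter). Compound 3 `O=[N+]([O-])c1cccc(Nc2nc(SCc3ccc(C(F)(F)F)cc3)nc3ccccc23)c1` gives 31500 nM, a move of an at least 1.5-fold lower number from compound 1 to compound 3 (0.20 log units; that floor lies within the scatter). Between those two, a 1.8-fold higher number from compound 2 to compound 3 (0.24 log units; within the scatter). Compound 4 `Fc1ccc(Nc2nc(SCc3ccc(C(F)(F)F)cc3)nc3ccccc23)cc1` is not yet measured; the change in it is 4-fluorophenyl in place of 2-(trifluoromethyl)phenyl on a nitrogen on an aromatic ring. Both measured exchanges of that group brought the number down from the limit, the one clearly and the other only at its floor, so a downward step is expected here too, estimated as an at least 2.0-fold lower number from compound 1 to compound 4 (0.30 log units; that floor lies within the scatter). Compound 4 is accordingly estimated at 25000 nM, within 8000 nM to 60000 nM.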

Compound 4, half-maximal inhibitory concentration: 15000 nM
Compound 4: the middle estimate sits 1.7-fold (0.22 log units) above what was measured; low and high end bracket the measured number.
By their numbers in this assay, from the lowest: compounds 4, 2 and 3 (each within the scatter of the next, the first and the last beyond it). At a limit, above all of these: compound 1.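

Putting 4-fluorophenyl on this nitrogen in place of 2-(trifluoromethyl)phenyl gives an at least 3.3-fold lower number from compound 1 to compound 4 (0.52 log units; beyond the scatter). That step is only a floor, since compound 1 holds a limit: the limit of > 50000 nM in this assay, at which 1 of the 4 values shown sits. Among the actual numbers, this group also opens the first gap beyond the scatter, a 2.1-fold lower number from compound 3 to compound 4 (0.32 log units; beyond the scatter), while its exchange with 3-chlorophenyl stays within the scatter, a 1.2-fold lower number from compound 2 to compound 4 (0.08 log units; within the scatter).

The compounds shown leave open how an amine or a carboxylic acid on this phenyl ring, or a longer chain in place of the ring, would read in this assay.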